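The source may hold more compounds than are shown below. What is called first, only, known or untested is meant among the compounds shown, and "the series" means these compounds.

In a functional assay on MCF7 cells (Homo sapiens) for inhibition (a higher number here means a weaker inhibitor, a lower number a stronger inhibitor), compound 1 (`O=C(CC(CC(=O)NC1Cc2ccccc2C1)c1ccc(Cl)cc1)NCCN1CCCCC1`) gives 35500 nM and compound 2 (`CCN(CC)CCNC(=O)CC(CC(=O)NC1Cc2ccccc2C1)c1ccc(Cl)cc1`) gives 75000 nM, so compound 2 holds the higher, weaker number of the pair. Next in the series is compound 3 (`O=C(CC(CC(=O)NC1Cc2ccccc2C1)c1ccc(Cl)cc1)NCCN1CCCC1`), with the change pyrrolidin-1-yl in place of diethylamino on a saturated chain carbon, two bonds along the chain from an amide-type nitrogen: pyrrolidin-1-yl in place of diethylamino, on a saturated chain carbon, two bonds along the chain from an amide-type nitrogen. Among the measured compounds shown here, one measured step bears on this: a 2.1-fold higher number from compound 1 to compound 2 (0.32 log units; beyond the scatter), with diethylamino in place of piperidin-1-yl. For the measured compounds named here, that step is modest and is the only guide available. Compound 3, like compound 1, carries a ring at this place, so a modest move to a lower number in this assay is expected, similar in size to that step. The estimated step is a 1.9-fold lower number from compound 2 to compound 3 (0.27 log units; within the scatter). For compound 3 the expected value is 40000 nM, with an estimated range of 18000 nM to 85000 nM.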

Compound 3, half-maximal inhibitory concentration: > 100000 nM
Compound 3 ended at the assay's limit; the forecaster's own chance of this, stated with the estimate: 5%; middle value at least 2.5-fold (0.39 log units) from the limit.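

In this assay compound 3 gives no number, only a limit of the assay: the limit of > 100000 nM in this assay, at which 1 of the 3 values shown sits. A ring at this place therefore does not by itself preserve the reading of compound 1: pyrrolidin-1-yl in place of piperidin-1-yl gives an at least 2.8-fold higher number from compound 1 to compound 3 (0.44 log units; beyond the scatter), so the identity of the ring matters here, and compound 1 holds the lowest number of the three. Against the open-chain diethylamino group the result is an at least 1.3-fold higher number from compound 2 to compound 3 (0.12 log units; that floor lies within the scatter); since that floor lies within the scatter, compound 3 cannot yet be ranked against compound 2.

On these data alone, it remains open whether morpholin-4-yl or 4-methylpiperazin-1-yl at this place would keep the reading of compound 1. Also open, as far as these compounds go, is whether a longer chain carrying the piperidin-1-yl group would lower or raise it.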